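Compound 4 Weighed Against Three Measured Relatives

A few compounds are considered here, and "the series" means these few. Any claim that something is new, unique, unknown or untested is made for them only; others in the source may bear on it.

Of the compounds shown here, three built on one shared core have so far been measured in a physicochemical assay for acid dissociation. Compound 1 `CCC(CC)c1ccc2c(NCCCNCc3cccc(OC)c3O)ccnc2c1` gives 9.47. Compound 2 `COc1cccc(CNCCCNc2ccnc3cc(-c4ccccc4)ccc23)c1O` gives 9.47 in this assay. Compound 3 `COc1cccc(CNCCCNc2ccnc3cc(Oc4cccc(N(C)C)c4)ccc23)c1O` gives 9.28 in this assay, the lowest of the three numbers, although compound 1, its nearest, and compound 2, its furthest, both sit within the scatter of it. The steps of no change at the digits printed from compound 1 to compound 2 (within the scatter), a number 0.19 log units lower from compound 1 to compound 3 (within the scatter) and a number 0.19 log units lower from compound 2 to compound 3 (within the scatter) each exchange the group on an aromatic carbon of the core, and none of them moves the number beyond the scatter.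

Compound 4 `COc1cccc(CNCCCNc2ccnc3cc(Cc4cc(C)cc(C)c4)ccc23)c1O` has not yet been measured. It differs from compound 3 in one place: 3,5-dimethylbenzyl in place of 3-(dimethylamino)phenoxy on an aromatic carbon. All three measured steps bear on this change, since each exchanges the group on this same aromatic carbon, and all three were small. The change from compound 3 to compound 4 is therefore expected to leave the number essentially where it stands, with an expected step of a number 0.12 log units higher from compound 3 to compound 4 (within the scatter). Compound 4 is estimated to give 9.4 in this assay, with a range from 9.1 to 9.7.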

Compound 4, acid dissociation constant: 9.47
Estimate against measurement, compound 4: 0.07 log units below; the range from low to high includes it.
By their numbers in this assay, from the lowest: compounds 3, 1, 2 and 4 (each within the scatter of the next).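

In this assay, the exchange of 3-(dimethylamino)phenoxy for 3,5-dimethylbenzyl on this aromatic carbon gives a small step (a number 0.19 log units higher from compound 3 to compound 4 (within the scatter)). This change removes a group holding nitrogen and oxygen, with hydrogen-bond acceptors, and puts in its place one of carbon only, with none, and the number does not move beyond the scatter. Among the compounds shown here, the steps from the two other measured compounds are just as small (no change at the digits printed from compound 2 to compound 4 (within the scatter); no change at the digits printed from compound 1 to compound 4 (within the scatter)), so across compounds 1, 2, 3 and 4 the position has taken four different groups with no step beyond the scatter, and no compound among them goes against this. Nothing shown gives a reason why the number stays put at this position.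

The compounds shown leave open whether a group of another kind on this same aromatic carbon, such as a carboxylic acid or a primary amine, would also stay within the scatter. For the compounds shown here, they also leave open what a change elsewhere on the shared core would do, for instance a longer chain in place of the one that all four compounds share.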